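This account rests on a few compounds, and the source may have more. Where it says the series, first, only, none or still open, it means among the compounds named here.

In a functional assay on SK-OV-3 cells (Homo sapiens) for antiproliferative activity, read by MTT assay (a lower number here means a stronger inhibitor, a higher number a weaker inhibitor), compound 3 `O=C(CCl)N1CCCc2cc(S(=O)(=O)N3CC(c4ccccc4)NC3=O)ccc21` has no number to stand on: its entry reads "not determined" (no result reported). Its relatives do have values. Compound 1 `O=C1NC(c2ccccc2)CN1S(=O)(=O)c1ccc2c(c1)CCCN2` gives 10400000 nM, and compound 2 `CC(C)COC(=O)N1CCCc2cc(S(=O)(=O)N3CC(c4ccccc4)NC3=O)ccc21` gives 5650 nM. Going by the values given here, the only measured step is a 1800-fold lower number from compound 1 to compound 2 (3.26 log units; beyond the scatter), with isobutoxycarbonyl in place of hydrogen on a nitrogen. Compound 4 `O=C(CCl)NC(=O)N1CCCc2cc(S(=O)(=O)N3CC(c4ccccc4)NC3=O)ccc21` differs from compound 3 by ((chloromethyl)carbonyl)amino in place of chloromethyl on a carbonyl carbon, with ((chloromethyl)carbonyl)amino in place of chloromethyl on a carbonyl carbon. That measured step bears only loosely on this change, and with no starting value, no size or direction can be expected from compound 3. The best anchor is compound 2 at 5650 nM, which also carries a carbonyl on that ring nitrogen. Compound 4 is therefore estimated at 3000 nM, with an expected range of 400 nM to 15000 nM.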

Compound 4, half-maximal inhibitory concentration: 6140 nM
Compound 4: middle estimate off by 2.0-fold (0.31 log units), on the low side; measured number inside the range.
By their numbers in this assay, from the lowest: compounds 2 and 4 (each within the scatter of the next); then compound 1.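

In this assay, the step of a 1.1-fold higher number from compound 2 to compound 4 (0.04 log units; within the scatter) lies within the scatter, with ((chloromethyl)carbonyl)amino in place of isobutoxy on a carbonyl carbon. The large step of a 1700-fold lower number from compound 1 to compound 4 (3.23 log units; beyond the scatter) shows that replacing the hydrogen on that nitrogen is not tied to the isobutoxycarbonyl of compound 2, since two different carbonyl-linked groups read alike here. No available data explain this similarity. On these data alone, whether a simple amine or a longer chain on the same carbonyl carbon would read alike remains open.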